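This account rests on a few compounds, and the source may have more. Where it says the series, first, only, none or still open, it means among the compounds named here.

The series shares the core of compound 1 `CCOC(=O)c1cnc(NCC2CCCCC2)n2nc(-c3ccco3)nc12` and is followed in a functional assay on CHO cells for antagonist activity at adenosine receptor A2b (Homo sapiens); on this read-out higher numbers stand for weaker inhibition and lower numbers for stronger inhibition. In this assay compound 1 gives > 10000 nM, which is a limit of the assay and not a number. Compound 2 `CCOC(=O)c1cnc(N2CCCCC2)n2nc(-c3ccco3)nc12` carries piperidin-1-yl on the aromatic carbon; in this assay compound 2 gives > 10000 nM, again only a limit. Compound 3 `CCOC(=O)c1cnc(N(C)C)n2nc(-c3ccco3)nc12` carries dimethylamino on the aromatic carbon; in this assay compound 3 gives > 10000 nM, also a limit. Compound 3 thus stands at the same limit as the other two, and none of the three can be ordered against each other. The steps a step that the two limits leave unreadable from compound 1 to compound 2, a step that the two limits leave unreadable from compound 1 to compound 3 and a step that the two limits leave unreadable from compound 2 to compound 3 have no readable size because of the limit of > 10000 nM in this assay, at which 3 of the 3 values shown sit.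

Compound 4 `CCOC(=O)c1cnc(NC2CCCCC2)n2nc(-c3ccco3)nc12` is not yet measured. It differs from compound 3 as follows: cyclohexylamino in place of dimethylamino on an aromatic carbon. For the measured compounds named here, no measured step bears readably on this change; the nearest ones, running from (cyclohexylmethyl)amino through piperidin-1-yl to dimethylamino, all sit at the limit. The expectation for compound 4 in this assay is therefore that it most likely also returns only a limit, with no step beyond the scatter expected from compound 3 to compound 4, written as a step that the limit leaves unreadable from compound 3 to compound 4. The estimate for compound 4 in this assay is 15000 nM, with an expected range from 4000 nM to 60000 nM.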

Compound 4, inhibition constant: > 10000 nM
Compound 4: only a limit was reported; the forecaster's own chance of this, stated with the estimate: 75%; the middle value lies beyond the limit too.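

In this assay compound 4 gives > 10000 nM, a limit and not a number. For the compounds shown here, no step from compound 1, compound 2 or compound 3 to compound 4 can be read: the limit of > 10000 nM in this assay, at which 4 of the 4 values shown sit. The compounds shown leave open how these amino groups rank against one another and whether any group at this place on the shared core gives a measurable value.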